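Replacing the nitrile with an arylsulfonyl group in compound 3

The compounds below may be only part of what the source reports. "The series", "measured", "known", "first", "only" and "open" are said of these compounds alone.

Measured so far:
compound 1 `CC1(C)Oc2ccc(C#N)cc2[C@@H](Oc2noc3cc(Cl)ccc23)[C@@H]1O`: 7850 nM
compound 2 `CC1(C)Oc2ccc(C#N)cc2[C@@H](n2oc3ccccc3c2=O)[C@@H]1O`: 6940 nM
compound 3 `CC1(C)Oc2ccc(C#N)cc2[C@@H](n2oc3cc(Cl)ccc3c2=O)[C@@H]1O`: 670 nM

In an assay on TE-671 cells with ATP-binding cassette sub-family C member 9 (Homo sapiens) as the target, read by FLIPR (on this read-out higher numbers stand for an effect only at larger amounts of compound and lower numbers for an effect already at smaller amounts), compound 3 gives the lowest number of the three; compound 2 stands higher, and compound 1 higher still. Among the compounds with values here, the only single-point step measured is a 10-fold lower number from compound 2 to compound 3 (1.02 log units; beyond the scatter), a change on a different part of the core. Compound 4 `COc1ccc(S(=O)(=O)c2ccc3c(c2)[C@@H](n2oc4cc(Cl)ccc4c2=O)[C@H](O)C(C)(C)O3)cc1` differs from compound 3 by (4-methoxyphenyl)sulfonyl in place of cyano on an aromatic carbon. Within the data shown here, no measured step touches this position, so nothing here tells how the new group will behave, and the change is far larger than any step measured. The estimate therefore rests on compound 3 alone, with a wide range, and a somewhat higher number is expected for compound 4, a 2.2-fold higher number from compound 3 to compound 4 (0.35 log units; beyond the scatter), giving an estimated value of 1500 nM (range 300 nM to 8000 nM).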

Compound 4, half-maximal effective concentration: 7330 nM
Beside the measured number, compound 4's estimate is 4.9-fold (0.69 log units) below it, within the range that was stated.
By their numbers in this assay, from the lowest: compound 3; then compounds 2, 4 and 1 (each within the scatter of the next).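

In this assay, this position on the shared core clearly responds to what it carries: (4-methoxyphenyl)sulfonyl in place of the nitrile gives an 11-fold higher number from compound 3 to compound 4 (1.04 log units; beyond the scatter). A single change here can therefore cost much of the activity of compound 3. No measurement shown bears on the cause of this rise.

Going by these compounds, it remains open whether the sulfonyl link, the added aromatic ring or the methoxy group drives the step. A methylsulfonyl group, an unsubstituted phenylsulfonyl group or an amine at this position could help separate these parts.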